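The source may hold more compounds than are shown below. What is called first, only, known or untested is meant among the compounds shown, and "the series" means these compounds.

Compound 1 `COc1ccc(-c2csc(N)c2C(=O)OCc2ccccc2F)cc1OC` reaches 100% in an assay on isolated protein for inhibition of protein kinase C zeta type (Homo sapiens), with stated times of 1 h and 2.5 min, tested at 30 uM (a lower number here means less inhibition, a higher number more inhibition at the concentration tested (going by the name of the read-out)), while compound 2 `COc1ccc(-c2csc(N)c2C(=O)OCc2ccc(F)cc2)cc1OC` gives only 2%, the lower of the two numbers recorded, with compound 1 standing a number 98 percentage points lower from compound 1 to compound 2 (beyond the scatter) above it. Compound 3 `COc1ccc(-c2csc(N)c2C(=O)OCc2ccncc2)cc1OC` differs from compound 2 by pyridin-4-yl in place of 4-fluorophenyl on a saturated chain carbon bound to an oxygen next to a carbonyl group. Among the measured compounds shown here, no measured step covers this exact change; the only step recorded, from compound 1 to compound 2, concerns a different exchange at the same place, and its large size shows that this region of the molecule strongly affects the result. Because compound 2 gives 2%, there is little room to fall further, so any change beyond the scatter would be upward. The outcome for compound 3 is estimated at 15%, within a range of 0% to 55%, which would mean an expected step of a number 13 percentage points higher from compound 2 to compound 3 (beyond the scatter).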

Compound 3, a percentage reported as inhibition, at one concentration (the size of the read-out at that concentration, not a potency): 53%
Compound 3: middle estimate off by 38 percentage points, on the low side; the range from low to high includes it.
By their numbers in this assay, from the lowest: compound 2; then compound 3; then compound 1.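

In this assay, the place on a saturated chain carbon bound to an oxygen next to a carbonyl group turns out to accept a ring with a hetero atom, and the exchange of 4-fluorophenyl for pyridin-4-yl gives a number 51 percentage points higher from compound 2 to compound 3 (beyond the scatter). The 2-fluorophenyl group still gives the higher number, with a number 47 percentage points lower from compound 1 to compound 3 (beyond the scatter), so the result here does not simply split into high and low: the three rings give three clearly separated readings. Nothing available explains these differences.

It remains open where an unsubstituted phenyl, pyridin-3-yl or pyridin-2-yl would fall among these three compounds. Also unresolved is whether a longer chain in place of the saturated chain carbon would preserve the reading of compound 1 or compound 3.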